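The source may report more compounds than this note shows. Statements on the series, on what has been measured and on what is new or still open speak of the compounds shown alone.

Compound 1 `c1ccc(Cn2ccc3nc(-c4ccccc4)nc-3c2)cc1`: in an ADME assay on MDBK cells (Bos taurus) for cytotoxicity (a higher number here means that more compound is tolerated, a lower number that less compound is tolerated), compound 1 gives > 100000 nM, a limit of the assay rather than a number.
Compound 2 `Brc1ccc(Cn2ccc3nc(-c4ccccc4)nc-3c2)cc1`: in this assay compound 2 gives 83000 nM.
Compound 3 `N#Cc1ccccc1Cn1ccc2nc(-c3ccccc3)nc-2c1`: in this assay compound 3 gives > 100000 nM, again a limit of the assay.

Compound 3 thus stands at the limit of > 100000 nM in this assay, at which 2 of the 3 values shown sit, so only a lower bound is known for it. Compound 4 `C(=C/c1ccccc1)\Cn1ccc2nc(-c3ccccc3)nc-2c1` is the next compound, and the change is 2-phenylethenyl in place of 2-cyanophenyl on a saturated chain carbon bound to an aromatic nitrogen. One measured step alters the group at this very place: an at least 1.2-fold higher number from compound 2 to compound 3 (0.08 log units; that floor lies within the scatter). A second step, an at least 1.2-fold lower number from compound 1 to compound 2 (0.08 log units; that floor lies within the scatter), swaps a substituent on that ring, and a third, a step that the two limits leave unreadable from compound 1 to compound 3, cannot be sized. For the measured compounds named here, none of the measured steps shows a shift beyond the scatter, so in this assay a step of a number no higher from compound 3 to compound 4 (the limit leaves the size open) is expected, that is, none beyond the scatter. Compound 4 is therefore expected to give 100000 nM, with a range from 40000 nM to 300000 nM.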

Compound 4, half-maximal cytotoxic concentration: 78000 nM
Compound 4: middle estimate off by 1.3-fold (0.11 log units), on the high side; measured number inside the range.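

Until now only phenyl groups, plain or substituted, stood at this place; compound 4 shows that 2-phenylethenyl, with its double bond outside the aromatic ring, gives a measurable number in this assay. Against the bromo compound the step is fully readable: a 1.1-fold lower number from compound 2 to compound 4 (0.03 log units; within the scatter). The other two steps, an at least 1.2-fold lower number from compound 3 to compound 4 (0.10 log units; that floor lies within the scatter) and an at least 1.2-fold lower number from compound 1 to compound 4 (0.10 log units; that floor lies within the scatter), give only floors, so their true size stays unknown: the limit of > 100000 nM in this assay, at which 2 of the 4 values shown sit.

On these data alone, whether an amine, a carboxylic acid or a longer chain at this place would move the number beyond the scatter stays open.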